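Piperazinyl aminothiophene ketones: change at the ring nitrogen

The source may hold more compounds than are shown below. What is called first, only, known or untested is meant among the compounds shown, and "the series" means these compounds.

Measured in an assay on CHO cells for displacement of a labelled ligand from adenosine receptor A1 (Homo sapiens), read by scintillation counting, with a stated time of 120 min, tested at 10 uM; on this read-out lower numbers stand for less inhibition and higher numbers for more inhibition at the one concentration tested (going by the name of the read-out):
compound 1 `Nc1scc(CN2CCN(c3ccncc3)CC2)c1C(=O)c1ccc(Cl)cc1`: 1%
compound 2 `Nc1scc(CN2CCN(c3ccc(C(F)(F)F)cc3)CC2)c1C(=O)c1cccc(C(F)(F)F)c1`: 0%
compound 3 `Nc1scc(CN2CCN(c3c(F)cccc3F)CC2)c1C(=O)c1cccc(C(F)(F)F)c1`: 0%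

Compound 1 stands together with compounds 2 and 3; the three values lie within the usual scatter of one another, all near the floor of this assay. Compound 4 `Nc1scc(CN2CCN(CCCc3ccc(Cl)cc3)CC2)c1C(=O)c1ccc(Cl)cc1` is not yet measured. It differs from compound 1 at one place, (3-(4-chlorophenyl)propyl in place of pyridin-4-yl on an amine nitrogen in a ring), so the group on the amine nitrogen in the ring is exchanged while the rest of the shared core is unchanged.

Within the data shown here, only one measured step bears on it: the step of no change at the digits printed from compound 2 to compound 3 (within the scatter), which also exchanged the group on that ring nitrogen and left the read-out unchanged within scatter. The change from compound 1 to compound 4 is larger, since a 3-(4-chlorophenyl)propyl chain enters in place of an aryl group, but nothing among the three measured compounds shows any movement in this assay. The expected step of a number 1 percentage points higher from compound 1 to compound 4 (within the scatter) is therefore none beyond the scatter. Compound 4 is estimated at 2%, within -5% to 12%.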

Compound 4, a percentage reported as inhibition, at one concentration (the size of the read-out at that concentration, not a potency): 0%
Beside the measured number, compound 4's estimate is 2 percentage points above it, and the stated range covers the measured number.
By their numbers in this assay, from the lowest: compounds 2, 3, 4 and 1 (each within the scatter of the next).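

In this assay, the group on the amine nitrogen in the ring now undergoes a much larger exchange than in the earlier aryl-for-aryl pair: 3-(4-chlorophenyl)propyl in place of pyridin-4-yl gives a number 1 percentage points lower from compound 1 to compound 4 (within the scatter) and nothing beyond it. The step removes the ring nitrogen of pyridin-4-yl with its hydrogen-bond acceptor and brings in a propyl chain and a chlorine, yet the read-out does not separate the two compounds. Nothing at hand bears on why the numbers stay this low.

All four compounds sit near the floor, so the set cannot tell whether this position is insensitive or whether the series gives no inhibition whatever stands there. Going by these compounds, whether a carboxylic acid or a primary amine at the end of a longer chain on that nitrogen would lift a compound off the floor stays open.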